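A few compounds are considered here, and "the series" means these few. Any claim that something is new, unique, unknown or untested is made for them only; others in the source may bear on it.

Measured compounds:
- compound 1, `COc1ccc(C2SCC(=O)N2n2c(CSc3nnc(-c4ccncc4)o3)nc3ccccc3c2=O)cc1`, 33.8%
- compound 2, `O=C1CSC(c2ccccc2)N1n1c(CSc2nnc(-c3ccncc3)o2)nc2ccccc2c1=O`, 30.1%
- compound 3, `O=C1CSC(c2ccc(O)cc2)N1n1c(CSc2nnc(-c3ccncc3)o2)nc2ccccc2c1=O`, 31.7%

These three compounds share one core and differ only in the group on the phenyl ring. In a functional assay on the whole organism (strain Charles-Foster albino) for inhibition, with Rattus norvegicus as the target, read by paw edema, at a dose of 50 mg/kg by the oral route (a lower number here means less inhibition, a higher number more inhibition at the dose given (going by the name of the read-out)), compound 1 gives 33.8%, compound 2 gives 30.1% and compound 3 gives 31.7%. The three values lie close together: a number 3.7 percentage points lower from compound 1 to compound 2 (within the scatter), a number 2.1 percentage points lower from compound 1 to compound 3 (within the scatter) and a number 1.6 percentage points higher from compound 2 to compound 3 (within the scatter). Compound 3 therefore sits among values that all fall within the scatter of one another, and nothing in the numbers sets it apart from compound 1 or compound 2.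

Compound 4, `O=C1CSC(c2ccc(Cl)cc2)N1n1c(CSc2nnc(-c3ccncc3)o2)nc2ccccc2c1=O`, is not yet measured. It differs from compound 3 in one place: chloro in place of hydroxy on an aromatic carbon. Among the measured compounds shown here, the steps that bear on this change are those at the same position: a number 1.6 percentage points higher from compound 2 to compound 3 (within the scatter), where the same hydroxy was put in, and a number 3.7 percentage points lower from compound 1 to compound 2 (within the scatter), where another group at that position was removed. Both were within the scatter, so no step beyond the scatter is expected for compound 4 in this assay, and the expected step is a number 0.7 percentage points lower from compound 3 to compound 4 (within the scatter). Compound 4 is estimated at 31%, within a range from 22% to 41%.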

Compound 4, a percentage reported as inhibition, in the whole organism at one dose (the size of the read-out at that dose, not a potency): 34.1%
For compound 4 the middle estimate is 3.1 percentage points below the measured one, within the range that was stated.
By their numbers in this assay, from the lowest: compounds 2, 3, 1 and 4 (each within the scatter of the next).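

In this assay, putting chloro in place of hydroxy removes the hydrogen-bond donor and acceptor counted for hydroxy, yet the result is a number 2.4 percentage points higher from compound 3 to compound 4 (within the scatter). Set against the other two compounds, the same position gives a number 4 percentage points higher from compound 2 to compound 4 (within the scatter) and a number 0.3 percentage points higher from compound 1 to compound 4 (within the scatter), so chloro joins hydrogen, hydroxy and methoxy without any step leaving the scatter, and the four compounds shown cannot be told apart by this read-out. No measurement is available that would explain why these groups read alike.

The compounds shown leave open whether any group at this position can give a step beyond the scatter in this assay, for instance an amine, a carboxylic acid or a longer chain such as butoxy. They also leave open whether chloro would read the same on another carbon of this ring, and whether the single dose used here hides differences among the compounds that a comparison across several doses might show.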